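Replacing the cyclopentyl group of compound 1

The compounds below may be only part of what the source reports. "The series", "measured", "known", "first", "only" and "open" are said of these compounds alone.

Compound 1 `Nc1ccc(Nc2nc(NC3CCCC3)c3ccccc3n2)cc1`: 15900 nM
Compound 2 `O=C(O)c1ccc(Nc2nc(NC3CCCC3)c3ccccc3n2)cc1`: 28700 nM

Within the data shown here, in a functional assay on A549 cells (Homo sapiens) for antiproliferative activity, read by sulforhodamine B assay, with a stated time of 48 h (on this read-out lower numbers stand for stronger inhibition of growth and higher numbers for weaker inhibition of growth), compound 1 gives 15900 nM, and it cannot be separated from compound 2, the only other measured compound. Among the measured compounds shown here, the single measured step is a 1.8-fold higher number from compound 1 to compound 2 (0.26 log units; within the scatter), for carboxy in place of amino on an aromatic carbon. Compound 3 `Nc1ccc(Nc2nc(NCCCO)c3ccccc3n2)cc1` keeps the amino group of compound 1 and changes another place: 3-hydroxypropyl in place of cyclopentyl on a nitrogen on an aromatic ring. For the measured compounds named here, no measured step covers this place, so the carboxy step is only a loose guide to how much this assay moves within this small set. A modest rise is expected, with little support and a wide margin. The expected change is a 1.4-fold higher number from compound 1 to compound 3 (0.14 log units; within the scatter). For compound 3 the estimated value is 22000 nM, with an expected range of 8000 nM to 60000 nM.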

Compound 3, concentration for 50% growth inhibition: 17100 nM
Estimate against measurement, compound 3: 1.3-fold (0.11 log units) above, and the stated range covers the measured number.
By their numbers in this assay, from the lowest: compounds 1, 3 and 2 (each within the scatter of the next).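

At the position on a nitrogen on an aromatic ring, the first measured change gives a 1.1-fold higher number from compound 1 to compound 3 (0.03 log units; within the scatter) in this assay, with 3-hydroxypropyl in place of cyclopentyl. For this pair, the number therefore holds within the scatter when the five-membered ring of carbon only gives way to an open chain carrying a hydrogen-bond donor and acceptor. No supporting data bear on why the two groups read alike.

Going by these compounds, whether an amine or a carboxylic acid in place of the hydroxyl at the end of the chain, or a longer chain, would also stay within the scatter remains open. The compounds shown contain no step beyond the scatter at this position, so how far a change here can move the number in this assay is also unresolved.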